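Swapping chloro for methyl on the aryl ring of compound 2

A few compounds are considered here, and "the series" means these few. Any claim that something is new, unique, unknown or untested is made for them only; others in the source may bear on it.

Measured so far:
Compound 1, `CC1(C)Oc2ccc(C#N)cc2[C@@H](NC(=O)Nc2cccnc2)[C@@H]1O`: 500 nM
Compound 2, `CC1(C)Oc2ccc(C#N)cc2[C@@H](/N=C(\NC#N)Nc2cccc(Cl)c2)[C@@H]1O`: 600 nM

Both compounds were tested in a functional assay (aorta) with Rattus norvegicus as the target; on this read-out lower numbers stand for stronger inhibition and higher numbers for weaker inhibition. Compound 1 gives 500 nM and compound 2 gives 600 nM; these two numbers lie within the usual scatter of each other, so nothing separates them, and compound 2 sits at the far end of a pair that is too close to rank. Within the data shown here, the two compounds also differ in more than one place, so no single step between them can be read.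

Compound 3, `Cc1cccc(N/C(=N/[C@@H]2c3cc(C#N)ccc3OC(C)(C)[C@H]2O)NC#N)c1`, has not yet been measured. It differs from compound 2 in one place: methyl in place of chloro on an aromatic carbon. Cut one bond further out, the change reads 3-chlorophenyl to 3-methylphenyl on the arylamino part of the cyanoguanidine.

Among the measured compounds shown here, no measured pair shows what this kind of exchange does here, so the expectation rests on the size of the change alone, a single heavy atom for another. The step from compound 2 to compound 3 in this assay is expected to be small, a 1.2-fold higher number from compound 2 to compound 3 (0.07 log units; within the scatter), most likely not beyond the scatter. Compound 3 is therefore estimated at 700 nM, with a range from 300 nM to 1600 nM.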

Compound 3, half-maximal inhibitory concentration: 1000 nM
Estimate against measurement, compound 3: 1.4-fold (0.15 log units) below; measured number inside the range.
By their numbers in this assay, from the lowest: compounds 1, 2 and 3 (each within the scatter of the next).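

Among these compounds, this is the first pair in the set that differs in one place only, so it is the first direct reading of a change on the aryl ring. In this assay, replacing chloro with methyl on this aromatic carbon gives a 1.7-fold higher number from compound 2 to compound 3 (0.22 log units; within the scatter), so this pair does not separate the two groups, and 3-chlorophenyl and 3-methylphenyl cannot be told apart on this read-out. Nothing measured here gives a reason for the size of this step, and a single pair cannot show whether it would hold elsewhere in the series.

Both groups tested on this carbon contain one heavy atom, so the compounds shown leave open whether a group of a different kind or size, such as an amine, a carboxylic acid, a methoxy group or a longer alkyl chain, would move the number beyond the scatter. From the compounds shown here alone, compound 1 differs from the other two compounds in more than one place, so its steps to them cannot be read, and the separate contributions of its pyridine-bearing urea side remain unknown.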